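Sulfonyl Aryl Switch: Methylphenyl to Difluorophenyl

The compounds below may be only part of what the source reports. "The series", "measured", "known", "first", "only" and "open" are said of these compounds alone.

Of the compounds shown here, three built on one shared core have been measured in an assay on MDA-MB-231 cells for binding affinity to C-X-C chemokine receptor type 4 (Homo sapiens), read by microscopy, with stated times of 10 min and 30 min; a lower number here means that less compound is needed, a higher number that more compound is needed for the effect. Compound 1 `O=C(NCc1ccc(CNS(=O)(=O)c2cccc(C(F)(F)F)c2)cc1)c1ccc(CNc2ncccn2)cc1` gives 1000 nM, compound 2 `O=C(NCc1ccc(CNS(=O)(=O)c2cccc(Cl)c2)cc1)c1ccc(CNc2ncccn2)cc1` gives 1 nM, and compound 3 `Cc1ccc(S(=O)(=O)NCc2ccc(CNC(=O)c3ccc(CNc4ncccn4)cc3)cc2)cc1` gives 100 nM. Compound 3 therefore stands second highest of the three numbers, nearest to compound 1 and furthest from compound 2. Both steps that reach it lie beyond the scatter: a 100-fold higher number from compound 2 to compound 3 (2.00 log units; beyond the scatter), and a 10-fold lower number from compound 1 to compound 3 (1.00 log units; beyond the scatter).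

Compound 4 `O=C(NCc1ccc(CNS(=O)(=O)c2ccc(F)c(F)c2)cc1)c1ccc(CNc2ncccn2)cc1` differs from compound 3 in one place: 3,4-difluorophenyl in place of 4-methylphenyl on a sulfonyl sulfur. The new group again carries halogen atoms on the aryl ring, as do the groups in compound 1 and compound 2, and those two compounds span the full range observed, so the direction of the step is open. Weighing the large step against compound 2 and the modest step against compound 1, compound 4 is expected to show a 3.3-fold lower number from compound 3 to compound 4 (0.52 log units; beyond the scatter) in this assay, with an estimated value of 30 nM and a range from 3 nM to 300 nM.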

Compound 4, effective concentration (reported as EC, without a stated level of effect): 100 nM
Compound 4: middle estimate off by 3.3-fold (0.52 log units), on the low side, and the stated range covers the measured number.
By their numbers in this assay, from the lowest: compound 2; then compounds 3 and 4 (each within the scatter of the next); then compound 1.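

On the sulfonyl sulfur, the change to 3,4-difluorophenyl shows no change at the digits printed from compound 3 to compound 4 (within the scatter) in this assay, so carrying halogen atoms on the aryl ring does not by itself set a compound apart from the 4-methylphenyl one. The other two comparisons show a 100-fold higher number from compound 2 to compound 4 (2.00 log units; beyond the scatter) and a 10-fold lower number from compound 1 to compound 4 (1.00 log units; beyond the scatter), so the three halogen-bearing groups at this position give three clearly separate numbers, and the 3-chlorophenyl group of compound 2 stands well apart from the 3,4-difluorophenyl group. Nothing shown here accounts for these differences.

The compounds shown leave open whether the low number of compound 2 goes with the chlorine atom itself or with where it sits on the ring, which a 4-chlorophenyl or a 3-bromophenyl group could test. Also open, going by these compounds, is how this position responds to a 3-methoxyphenyl group or to a non-aromatic group such as cyclohexyl.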